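The compounds below may be only part of what the source reports. "The series", "measured", "known", "first", "only" and "open" are said of these compounds alone.

Three compounds in this set share one core, a hydroxy-dicarboxylic acid linked through a sulfur to a saturated chain that ends in an aromatic ring. Compound 1 `O=C(O)CC(O)(CSCCCCCc1ccc(Cl)cc1Cl)C(=O)O` carries a dichlorophenyl on a shorter chain, compound 2 `O=C(O)CC(O)(CSCCCCCCc1ccc(Cl)cc1Cl)C(=O)O` the same ring on a chain one carbon longer, and compound 3 `COc1ccc(CCCCCCSCC(O)(CC(=O)O)C(=O)O)cc1` a methoxyphenyl on the longer chain. In an assay on isolated protein for inhibition of ATP-citrate synthase (Rattus norvegicus) (a lower number here means a stronger inhibitor, a higher number a weaker inhibitor), compound 1 gives 6800 nM, compound 2 gives 3300 nM, and compound 3 gives 280000 nM. Compound 2 therefore stands as the strongest inhibitor of the three, with compound 1 nearest and compound 3 furthest away.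

For the measured compounds named here, the one change between measured neighbours that touches the aromatic end is the step from compound 2 to compound 3 an 85-fold higher number from compound 2 to compound 3 (1.93 log units; beyond the scatter), which shows how much the ring at the end of the chain matters.

Compound 4 `O=C(O)CC(O)(CSCCCCCCc1c(Cl)cc(Cl)cc1-c1ccccc1)C(=O)O` keeps the dichlorophenyl and the longer chain of compound 2 and adds (phenyl in place of hydrogen on an aromatic carbon). Going by the values given here, no measured step shows such an addition, so the expectation rests only on the large sensitivity of this position. A modest shift toward a lower number is expected, as a 1.3-fold lower number from compound 2 to compound 4 (0.12 log units; within the scatter), with wide uncertainty. For compound 4 the estimated value in this assay is 2500 nM, within a range from 600 nM to 10000 nM.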

Compound 4, inhibition constant: 10000 nM
Beside the measured number, compound 4's estimate is 4.0-fold (0.60 log units) below it, within the range that was stated.
By their numbers in this assay, from the lowest: compound 2; then compounds 1 and 4 (each within the scatter of the next); then compound 3.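

In this assay, putting phenyl in place of hydrogen on an aromatic carbon, ortho to a large group and meta to two chloro groups, gives a 3.0-fold higher number from compound 2 to compound 4 (0.48 log units; beyond the scatter): a modest loss of strength, but one beyond the scatter. For the compounds shown here, the only earlier change at this end of the molecule was the swap of the whole substituted ring, an 85-fold higher number from compound 2 to compound 3 (1.93 log units; beyond the scatter), so the new step shows that this end does not respond to every change with a large shift, and that even a group as big as an extra phenyl can be added here at a modest cost. The material at hand offers no independent measurement that would explain the higher number for compound 4.

The compounds shown carry only hydrogen or phenyl at this aromatic carbon, so it stays open whether a smaller group such as methyl, or a phenyl bearing an amine or a carboxylic acid, would give a lower or a higher number. On these data alone, it also stays open whether the same phenyl would shift the number to a similar degree on the shorter chain of compound 1.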